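Methyl in Place of Hydrogen, Tested Twice

This account rests on a few compounds, and the source may have more. Where it says the series, first, only, none or still open, it means among the compounds named here.

Measured in a functional assay on MCF7 cells (Homo sapiens) for antiproliferative activity; a higher number here means a weaker inhibitor, a lower number a stronger inhibitor:
compound 1 `Cc1c(O)ccc2cc(-n3cc(-c4ccccc4)nn3)c(=O)oc12` gives 25200 nM
compound 2 `CO[C@@H]1[C@@H](O)[C@@H](O)[C@H](Oc2ccc3c(c2C)OC(=O)C(n2cc(-c4ccccc4)nn2)C3)OC1(C)C` gives 64400 nM
compound 3 `Cc1ccc(-c2cn(-c3cc4ccc(O)c(C)c4oc3=O)nn2)cc1` gives 23200 nM

Compound 2 stands highest of the three, with compound 1 nearest and compound 3 furthest, both gaps beyond the scatter. How the core of compound 2 differs from the core of compound 1 is not broken down here.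

Compound 3 differs from compound 1 by methyl in place of hydrogen on an aromatic carbon and the step was a 1.1-fold lower number from compound 1 to compound 3 (0.04 log units; within the scatter). Compound 4 `CO[C@@H]1[C@@H](O)[C@@H](O)[C@H](Oc2ccc3c(c2C)OC(=O)C(n2cc(-c4ccc(C)cc4)nn2)C3)OC1(C)C` is not yet measured; it differs from compound 2 by methyl in place of hydrogen on an aromatic carbon, the same change made on a different core, and it is the only other occurrence of this change among the compounds shown.

Resting on the step from compound 1 to compound 3, compound 4 is expected to sit close to compound 2, the estimated step being a 1.1-fold lower number from compound 2 to compound 4 (0.03 log units; within the scatter). Because 64400 nM for compound 2 is already high, compound 4 is estimated at 60000 nM, between 25000 nM and 150000 nM.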

Compound 4, half-maximal inhibitory concentration: > 100000 nM
Compound 4 ended at the assay's limit; the forecaster's own chance of this, stated with the estimate: 25%; at least 1.6-fold (0.22 log units) between middle value and limit.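

Compound 4 gives > 100000 nM in this assay, which is a limit of the assay and not a number. As far as these compounds go, on the core of compound 2, methyl in place of hydrogen on the aromatic carbon therefore reads only as a floor, an at least 1.5-fold higher number from compound 2 to compound 4 (0.19 log units; that floor lies within the scatter), and the true size of the step stays unknown. This shows no sign of a gain in either series, yet it does not show that the change carries over from one core to the other, nor that it behaves differently on each: the same change on two cores in this assay, a 1.1-fold lower number (0.04 log units; within the scatter) from compound 1 to compound 3 and an at least 1.5-fold higher number (0.19 log units; that floor lies within the scatter) from compound 2 to compound 4; the limit leaves it open whether they differ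

The compounds shown hold only hydrogen or methyl at this place on the phenyl, which leaves open how a methoxy, a chlorine, an amine or a carboxylic acid there would read in this assay. They also leave open which part of the difference between the core of compound 1 and the core of compound 2 accounts for the gap between those two compounds.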